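A few compounds are considered here, and "the series" means these few. Any claim that something is new, unique, unknown or untested is made for them only; others in the source may bear on it.

Measured so far:
compound 1, `COc1ccc(-c2ccnc(Nc3ccc(Cl)cc3Cl)n2)cc1` — 839 nM in an assay on isolated protein for inhibition of phosphatidylinositol 4,5-bisphosphate 3-kinase catalytic subunit beta isoform (Homo sapiens); a higher number here means a weaker inhibitor, a lower number a stronger inhibitor
compound 2, `Cc1ccc(-c2ccnc(Nc3ccc(Cl)cc3Cl)n2)cc1` — in this assay compound 2 gives only a limit, > 1000 nM
compound 3, `Cc1cccc(Nc2nccc(-c3ccc(Cl)cc3Cl)n2)c1` — 851 nM

Compounds 2 and 3 are built from the same atoms joined differently; the difference between the two cores is not broken down here. From compound 2 to compound 1 the change is methoxy in place of methyl on an aromatic carbon and gives an at least 1.1-fold lower number from compound 2 to compound 1 (0.07 log units; that floor lies within the scatter), the starting value being a limit (the limit of > 1000 nM in this assay, at which 1 of the 3 values shown sits). Compound 3 and compound 1 sit within the scatter of each other, so no order can be read between them.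

Compound 4, `COc1cccc(Nc2nccc(-c3ccc(Cl)cc3Cl)n2)c1`, is not yet measured. It differs from compound 3 by methoxy in place of methyl on an aromatic carbon, the same kind of change as from compound 2 to compound 1, but the place differs: there the methoxy stands para to a large group, here meta to a large group. In this assay the step from compound 3 to compound 4 is expected to be small, a 1.2-fold lower number from compound 3 to compound 4 (0.08 log units; within the scatter), resting on the step from compound 2 to compound 1, an at least 1.1-fold lower number from compound 2 to compound 1 (0.07 log units; that floor lies within the scatter), which lies within the scatter. Compound 4 is therefore estimated at 700 nM, with a range from 300 nM to 1600 nM.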

Compound 4, half-maximal inhibitory concentration: 893 nM
Beside the measured number, compound 4's estimate is 1.3-fold (0.11 log units) below it; low and high end bracket the measured number.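

In this assay, methoxy in place of methyl on an aromatic carbon gives a 1.0-fold higher number from compound 3 to compound 4 (0.02 log units; within the scatter), so no order can be read between these two compounds. Set beside the same change on the other core, the comparison reads: the same change on two cores in this assay, an at least 1.1-fold lower number (0.07 log units; that floor lies within the scatter) from compound 2 to compound 1 and a 1.0-fold higher number (0.02 log units; within the scatter) from compound 3 to compound 4; the limit leaves it open whether they differ. The notes therefore show neither that the change carries over from one core to the other with the same size nor that its size depends on the core, and compound 2 gives only a limit, not a number: the limit of > 1000 nM in this assay, at which 1 of the 4 values shown sits.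

The compounds shown leave open what other groups would give at this place on either core, for instance an amine, a carboxylic acid or a longer chain such as ethoxy. Also open, going by these compounds, is whether a pair on these two cores with both members measured as numbers, such as a hydroxyl against a nitrile, would give steps that can be compared in this assay.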